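The source may report more compounds than this note shows. Statements on the series, on what has been measured and on what is new or still open speak of the compounds shown alone.

In a functional assay on HCT-116 cells (Homo sapiens) for antiproliferative activity, read by MTT assay, with a stated time of 48 h (on this read-out higher numbers stand for weaker inhibition and lower numbers for stronger inhibition), three compounds sharing one core have been measured: compound 1 `COc1ccc(CN(C(=O)CSc2nc3ccccc3s2)c2cc(OC)c(OC)c(OC)c2)cc1C` gives 17100 nM, compound 2 `COc1ccc(CN(C(=O)CSc2nc3ccccc3s2)c2cc(OC)c(OC)c(OC)c2)cc1N=[N+]=[N-]` gives 2860 nM, and compound 3 `COc1ccc(CN(C(=O)CSc2nc3ccccc3s2)c2cc(OC)c(OC)c(OC)c2)cc1[N+](=O)[O-]` gives 1280 nM, the lowest of the three numbers. Exchanging one group on an aromatic carbon shifted the read-out, with a 13-fold lower number from compound 1 to compound 3 (1.13 log units; beyond the scatter) for nitro in place of methyl, a 6.0-fold lower number from compound 1 to compound 2 (0.78 log units; beyond the scatter) for azido in place of methyl, and a 2.2-fold lower number from compound 2 to compound 3 (0.35 log units; beyond the scatter) for nitro in place of azido. Compound 4 `COc1cc(CN(C(=O)CSc2nc3ccccc3s2)c2cc(OC)c(OC)c(OC)c2)cc(OC)c1OC` differs from compound 3 by 3,4,5-trimethoxyphenyl in place of 4-methoxy-3-nitrophenyl on a saturated chain carbon bound to an amide-type nitrogen. Within the data shown here, no measured step makes this exact exchange, but those steps show that the number can move widely with changes on this group. Since compound 3 stands lowest at 1280 nM, a modest rise rather than a further fall is expected in this assay. The expected change is a 3.1-fold higher number from compound 3 to compound 4 (0.49 log units; beyond the scatter). The estimate for compound 4 is 4000 nM, within an expected range of 1000 nM to 16000 nM.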

Compound 4, half-maximal inhibitory concentration: 65300 nM
Compound 4: the middle estimate sits 16-fold (1.21 log units) below what was measured, and the stated range ends below it.
By their numbers in this assay, from the lowest: compound 3; then compound 2; then compound 1; then compound 4.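

In this assay the exchange to 3,4,5-trimethoxyphenyl on a saturated chain carbon bound to an amide-type nitrogen gave a 51-fold higher number from compound 3 to compound 4 (1.71 log units; beyond the scatter) and a 23-fold higher number from compound 2 to compound 4 (1.36 log units; beyond the scatter) as its largest steps, so this position can push the number up as well as down. Even against the methyl-bearing group it gave a 3.8-fold higher number from compound 1 to compound 4 (0.58 log units; beyond the scatter) on the same exchange, which leaves compound 4 highest of the four. No measured evidence accounts for these shifts. The whole group changes at once here, so the contribution of each methoxy group remains unresolved. As far as these compounds go, whether an amine or a carboxylic acid in place of the nitro group would keep the number low also remains open.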